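Chloro for Methoxy Across Two Cores

The compounds below may be only part of what the source reports. "The series", "measured", "known", "first", "only" and "open" are said of these compounds alone.

Compound 1 `COc1ccc(C(=O)Nc2nc(-c3cc(OC)c(OC)c(OC)c3)cs2)cc1` opens the set. In a functional assay on MDA-MB-231 cells (Homo sapiens), read by microscopy and transwell migration, with a stated time of 24 h (on this read-out higher numbers stand for weaker inhibition and lower numbers for stronger inhibition), compound 1 gives > 25000 nM, which is a limit of the assay rather than a number. Compound 2 `COc1cc(-c2csc(NC(=O)c3ccc(Cl)cc3)n2)cc(OC)c1OC` differs from it by chloro in place of methoxy on an aromatic carbon. In this assay compound 2 gives > 25000 nM, again a limit of the assay. The step that the two limits leave unreadable from compound 1 to compound 2 therefore cannot be sized, because the limit of > 25000 nM in this assay, at which 2 of the 3 values shown sit, covers both ends of it. Compound 3 `COc1ccc(C(=O)/N=c2\scc(-c3cc(OC)c(OC)c(OC)c3)n2C)cc1` stands on a different core; the difference between the two cores is not broken down here. In this assay, among the measured compounds shown here, compound 3 gives 8040 nM, the only number among the three values so far. Compound 4 `COc1cc(-c2cs/c(=N\C(=O)c3ccc(Cl)cc3)n2C)cc(OC)c1OC` differs from compound 3 by chloro in place of methoxy on an aromatic carbon, the same change as that from compound 1 to compound 2, made at the same place. Since the earlier step is unreadable, the expectation for compound 4 rests on compound 3 alone, and the expected step of a 1.2-fold higher number from compound 3 to compound 4 (0.09 log units; within the scatter) is kept close to neutral with a wide spread. Compound 4 is estimated to give 10000 nM in this assay, between 3000 nM and 30000 nM.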

Compound 4, half-maximal inhibitory concentration: 758 nM
For compound 4 the middle estimate is 13-fold (1.12 log units) above the measured one; measured number below the stated range.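

On the core of compound 3, the change from 4-methoxyphenyl to 4-chlorophenyl has a large effect in this assay, with an 11-fold lower number from compound 3 to compound 4 (1.03 log units; beyond the scatter). On the core of compound 1 the same change cannot be read, because compound 1 and compound 2 both stand at a limit of the assay and not at a number: the limit of > 25000 nM in this assay, at which 2 of the 4 values shown sit. The pair of cores therefore gives one sized step rather than two, which shows that the change can matter on one core but neither shows that it carries over from one core to the other nor shows that it fails to.

The compounds shown leave open whether this step belongs to chloro in particular or would also appear with fluoro, bromo or trifluoromethyl at the same place on the core of compound 3. They also leave open what an amine or a carboxylic acid would do there.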